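Trimming an amide side chain on a shared core

The source may report more compounds than this note shows. Statements on the series, on what has been measured and on what is new or still open speak of the compounds shown alone.

Measured so far:
Compound 1 `O=C1O[C@@H](CN2CCC(O)CC2)CN1c1ccc(-n2cc(-c3ccccn3)cn2)c(F)c1` gives 45900 nM in a physicochemical assay for solubility, read by HPLC, with a stated time of 24 h; on this read-out lower numbers stand for lower solubility and higher numbers for higher solubility.
Compound 2 `O=C1O[C@@H](Cn2ccnn2)CN1c1ccc(-n2cc(-c3ccccn3)cn2)c(F)c1` gives 247000 nM in this assay.
Compound 3 `CCC(=O)NC[C@H]1CN(c2ccc(-n3cc(-c4ccccn4)cn3)c(F)c2)C(=O)O1` gives 147000 nM in this assay.

Compound 3 holds the second highest of the three numbers. Its nearest neighbour is compound 2, and that gap, a 1.7-fold lower number from compound 2 to compound 3 (0.23 log units; within the scatter), is within the scatter, so the two cannot be told apart. The gap from compound 1, a 3.2-fold higher number from compound 1 to compound 3 (0.51 log units; beyond the scatter), is beyond the scatter.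

Compound 4 `O=CNC[C@H]1CN(c2ccc(-n3cc(-c4ccccn4)cn3)c(F)c2)C(=O)O1` differs from compound 3 in one place: hydrogen in place of ethyl on a carbonyl carbon, so the propanoylamino group becomes a formylamino group on the same chain carbon. Among the compounds with values here, no measured step shortens an amide chain; each of a 5.4-fold higher number from compound 1 to compound 2 (0.73 log units; beyond the scatter), a 3.2-fold higher number from compound 1 to compound 3 (0.51 log units; beyond the scatter) and a 1.7-fold lower number from compound 2 to compound 3 (0.23 log units; within the scatter) replaces the whole group on that chain carbon. Within the data shown here, the one swap between two uncharged groups there, a 1.7-fold lower number from compound 2 to compound 3 (0.23 log units; within the scatter), stayed within the scatter, and removing two carbons from the chain is a smaller change than either swap. The expected step is therefore small, a 1.2-fold higher number from compound 3 to compound 4 (0.09 log units; within the scatter), and not clearly beyond the scatter. Compound 4 is estimated at 180000 nM, with a range from 80000 nM to 400000 nM.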

Compound 4, solubility: 217000 nM
For compound 4 the middle estimate is 1.2-fold (0.08 log units) below the measured one; the measured number falls inside the stated range.
By their numbers in this assay, from the lowest: compound 1; then compounds 3, 4 and 2 (each within the scatter of the next).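

On this chain carbon, the amide of compound 3 can lose its ethyl group without a readable shift in this assay (a 1.5-fold higher number from compound 3 to compound 4 (0.17 log units; within the scatter)). The formylamino group of compound 4 also cannot be told apart from the 1H-1,2,3-triazol-1-yl group (a 1.1-fold lower number from compound 2 to compound 4 (0.06 log units; within the scatter)), yet the gap from the 4-hydroxypiperidin-1-yl group remains beyond the scatter (a 4.7-fold higher number from compound 1 to compound 4 (0.67 log units; beyond the scatter)), leaving compound 1 as the only one of the four that stands apart. Nothing here accounts for how little the ethyl group matters.

From the compounds shown here alone, it remains open whether a longer chain on the carbonyl carbon, such as butanoyl, would also stay level with compound 3. Going by these compounds, it is equally open whether a simple amine such as dimethylamino on the chain carbon would sit with compound 1 or with compounds 2, 3 and 4.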